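Rearranging the Acid Chain of Compound 2

This account rests on a few compounds, and the source may have more. Where it says the series, first, only, none or still open, it means among the compounds named here.

For the measured compounds named here, in an ADME assay on the whole organism (strain CD-1) for pharmacokinetics, with Mus musculus as the target, at a dose of 3 mg/kg by the intravenous route (on this read-out higher numbers stand for fast clearance and lower numbers for slow clearance), compound 1 `C[C@@H](CCCOc1ccccc1CN(C)C(=O)c1ccc(-c2ccco2)cc1)CC(=O)O` gives 1.3 mL/min/kg and compound 2 `C/C(=C\CCCOc1ccccc1CN(C)C(=O)c1ccc(-c2ccco2)cc1)C(=O)O` gives 4 mL/min/kg, which makes compound 2 the higher of only two numbers. Compound 3 `C/C(=C\COc1ccccc1CN(C)C(=O)c1ccc(-c2ccco2)cc1)CCC(=O)O` has the same atoms as compound 2 but joins them differently: 4-carboxy-2-methylbut-1-en-1-yl in place of 4-carboxypent-3-en-1-yl on a saturated chain carbon bound to an oxygen on an aromatic ring. In plain terms, 4-carboxy-2-methylbut-1-en-1-yl stands in place of 4-carboxypent-3-en-1-yl on a saturated chain carbon bound to an oxygen on an aromatic ring.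

Going by the values given here, only one measured step bears on this change, since it also altered the chain that carries the acid. That step, a 3.1-fold higher number from compound 1 to compound 2 (0.49 log units; beyond the scatter), is modest, although it lies beyond the scatter. A single step cannot show which way a different rearrangement will go, so no clear shift in this assay is expected, though a modest move either way remains possible. The estimated change is a 1.1-fold lower number from compound 2 to compound 3 (0.06 log units; within the scatter). For compound 3 the expected value is 3.5 mL/min/kg, with an estimated range from 1.3 mL/min/kg to 9 mL/min/kg.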

Compound 3, clearance: 15 mL/min/kg
The estimate for compound 3 lay 4.3-fold (0.63 log units) below the measured number; the measured number lies above the stated range.
By their numbers in this assay, from the lowest: compound 1; then compound 2; then compound 3.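

In this assay the two chains hold the same atoms, yet 4-carboxy-2-methylbut-1-en-1-yl in place of 4-carboxypent-3-en-1-yl gives a 3.8-fold higher number from compound 2 to compound 3 (0.57 log units; beyond the scatter) in clearance, so this position responds to how the atoms of the chain are joined and not only to which atoms are present. Set against the saturated 3-(carboxymethyl)butyl chain of compound 1, the new chain gives a 12-fold higher number from compound 1 to compound 3 (1.06 log units; beyond the scatter) and this is the widest gap among the three compounds, which now fall in a clear order rather than forming a single pair. Nothing measured here accounts for the size or direction of either step.

Compound 3 differs from compound 2 in both where its double bond lies and where its methyl branch lies, so the two contributions remain tangled, and a saturated 4-carboxy-2-methylbutyl chain would help to separate them. From the compounds shown here alone, it also remains open whether the same rearrangement would change clearance in a similar way if a tetrazole stood in place of the carboxylic acid, or with a longer chain.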